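The source may report more compounds than this note shows. Statements on the series, on what has been measured and on what is new or still open speak of the compounds shown alone.

Compound 1 `O=C1C=CC(O)(c2cc3ccccc3n2S(=O)(=O)c2ccccc2)C=C1` is the starting point of this set; in a functional assay on HCT-116 cells (Homo sapiens) for inhibition, read by MTT assay, with a stated time of 72 h (on this read-out lower numbers stand for stronger inhibition and higher numbers for weaker inhibition), compound 1 gives 30 nM. Compound 2 `O=C1C=CC(O)(c2cc3ccc(F)cc3n2S(=O)(=O)c2ccccc2)C=C1` carries fluoro in place of hydrogen on an aromatic carbon, and the step of no change at the digits printed from compound 1 to compound 2 (within the scatter) leaves compound 2 at 30 nM. Compound 3 `O=C1C=CC(O)(c2cc3ccccc3n2S(=O)(=O)c2ccc(CCC(=O)O)cc2)C=C1` differs from compound 1 by 2-carboxyethyl in place of hydrogen on an aromatic carbon; the step of no change at the digits printed from compound 1 to compound 3 (within the scatter) gives compound 3 30 nM in this assay. Compound 4 `O=C1C=CC(O)(c2cc3ccc(F)cc3n2S(=O)(=O)c2ccc(CCC(=O)O)cc2)C=C1` has not been measured. It differs from compound 3 by fluoro in place of hydrogen on an aromatic carbon, the same change, at the same place, as that from compound 1 to compound 2. Compound 4 is expected to show no change at the digits printed from compound 3 to compound 4 (within the scatter) because the earlier instance gave no change at the digits printed from compound 1 to compound 2 (within the scatter). Compound 4 is thus estimated at 30 nM, with a likely range from 15 nM to 60 nM.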

Compound 4, half-maximal inhibitory concentration: 30 nM
Compound 4: middle estimate and measured number agree at the digits printed; the measured number falls inside the stated range.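

In this assay the fluoro change on the core of compound 3 gives no change at the digits printed from compound 3 to compound 4 (within the scatter), which matches its earlier instance: the same change on two cores in this assay, no change at the digits printed (within the scatter) from compound 1 to compound 2 and no change at the digits printed (within the scatter) from compound 3 to compound 4, 1.0-fold (0.00 log units) apart, within the scatter of two such steps

The 2-carboxyethyl change gives no change at the digits printed from compound 2 to compound 4 (within the scatter), and it too matches its earlier instance: the same change on two cores in this assay, no change at the digits printed (within the scatter) from compound 1 to compound 3 and no change at the digits printed (within the scatter) from compound 2 to compound 4, 1.0-fold (0.00 log units) apart, within the scatter of two such steps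

So each change carries between these two cores without altering the read-out, but steps that show no shift cannot tell whether a change that did shift the value would carry over in the same way, and they say nothing about any other core.

The compounds shown leave open whether a chloro or methoxy group in place of the fluoro would also leave the value level. They also leave open whether an amine or a longer chain ending in a carboxylic acid could stand in place of the 2-carboxyethyl group with the same result.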